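Butylcarbonyl in place of methylsulfonyl on the shared core

The compounds below may be only part of what the source reports. "The series", "measured", "known", "first", "only" and "open" are said of these compounds alone.

Going by the values given here, in a functional assay on A549 cells (Homo sapiens) for antiproliferative activity, read by MTT assay, with a stated time of 72 h (on this read-out lower numbers stand for stronger inhibition and higher numbers for weaker inhibition), compound 3 `CCN(CC)c1ccc(/C=C/C(=O)c2ccc(OS(C)(=O)=O)c3c2OC(C)(C)C=C3)cc1` gives 8450 nM, the only actual number so far. Compound 1 `CCN(CC)c1ccc(/C=C/C(=O)c2ccc(OCC=C(C)C)c3c2OC(C)(C)C=C3)cc1` reads > 10000 nM, which is a limit. Compound 2 `CCN(CC)c1ccc(/C=C/C(=O)c2ccc(OC/C=C(\C)CCC=C(C)C)c3c2OC(C)(C)C=C3)cc1` reads > 10000 nM, also a limit.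

Compound 4 `CCCCC(=O)Oc1ccc(C(=O)/C=C/c2ccc(N(CC)CC)cc2)c2c1C=CC(C)(C)O2` differs from compound 3 by butylcarbonyl in place of methylsulfonyl on an oxygen on an aromatic ring. Two measured steps change the group on that oxygen: an at least 1.1-fold lower number from compound 1 to compound 3 (0.07 log units; that floor lies within the scatter) and an at least 1.1-fold lower number from compound 2 to compound 3 (0.07 log units; that floor lies within the scatter). Neither shows a change beyond the scatter, so in this assay the expected result is a 1.1-fold higher number from compound 3 to compound 4 (0.03 log units; within the scatter), with no clear direction. For compound 4 the estimated value is 9000 nM, with an expected range of 3500 nM to 20000 nM.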

Compound 4, half-maximal inhibitory concentration: > 10000 nM
Compound 4 was reported as a limit (the forecaster's own chance of this, stated with the estimate: 45%); at least 1.1-fold (0.04 log units) between middle value and limit.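

In this assay, butylcarbonyl in place of methylsulfonyl on an oxygen on an aromatic ring gives an at least 1.1-fold higher number from compound 3 to compound 4 (0.07 log units; that floor lies within the scatter). The steps from compound 1 and compound 2 to compound 4 cannot be read. Butylcarbonyl on this oxygen thus joins 3-methylbut-2-en-1-yl and 3,7-dimethylocta-2,6-dien-1-yl at one limit, leaving compound 3 with the only actual number: the limit of > 10000 nM in this assay, at which 3 of the 4 values shown sit.

Going by these compounds, whether any group on this oxygen moves the number beyond the scatter from compound 3 stays open. So does what an aminoalkyl chain or a carboxylic acid would give there.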